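From pyrimidin-4-yl to 2-fluorophenyl: cytotoxicity notes

The source may hold more compounds than are shown below. What is called first, only, known or untested is meant among the compounds shown, and "the series" means these compounds.

Three measured compounds share one core and differ in the group on a saturated chain carbon bound to an amide-type nitrogen: compound 1 `Cc1cc(C)cc(S(=O)(=O)c2c(C(=O)NCC(=O)NCc3ccco3)[nH]c3ccc(Cl)cc23)c1` and compound 2 `Cc1cc(C)cc(S(=O)(=O)c2c(C(=O)NCC(=O)NCCn3c(C)cnc3[N+](=O)[O-])[nH]c3ccc(Cl)cc23)c1` and compound 3 `Cc1cc(C)cc(S(=O)(=O)c2c(C(=O)NCC(=O)NCc3ccncn3)[nH]c3ccc(Cl)cc23)c1` in that order. In an ADME assay on MT4 cells (Homo sapiens) for cytotoxicity, read by MTT assay (a higher number here means that more compound is tolerated, a lower number that less compound is tolerated), compound 3 gives > 48800 nM as a limit of the assay and not as a number. Compound 1 gives > 50000 nM as a limit too. Within the data shown here, compound 2 gives 24500 nM as the one actual number of the set.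

The next structure is compound 4 `Cc1cc(C)cc(S(=O)(=O)c2c(C(=O)NCC(=O)NCc3ccccc3F)[nH]c3ccc(Cl)cc23)c1` and the change is 2-fluorophenyl in place of pyrimidin-4-yl on a saturated chain carbon bound to an amide-type nitrogen with 2-fluorophenyl in place of pyrimidin-4-yl, read one bond further out as (pyrimidin-4-yl)methyl to 2-fluorobenzyl.

All three measured steps sit at this same place. The swap closest in kind is a step that the two limits leave unreadable from compound 1 to compound 3 and it offers no size. The two readable floors are an at least 2.0-fold lower number from compound 1 to compound 2 (0.30 log units; that floor lies within the scatter) and an at least 1.9-fold higher number from compound 2 to compound 3 (0.29 log units; that floor lies within the scatter) and neither leaves the scatter. Given compound 3 in an at least 1.9-fold higher number from compound 2 to compound 3 (0.29 log units; that floor lies within the scatter) no step beyond the scatter is expected in this assay and no firm direction is claimed. The expected step is an at least 1.2-fold lower number from compound 3 to compound 4 (0.08 log units; that floor lies within the scatter) and it stays a rough expectation. Compound 4 is expected to read 40000 nM with an estimated range from 15000 nM to 60000 nM and may well return as a limit again.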

Compound 4, half-maximal cytotoxic concentration: > 47300 nM
Compound 4 gave a limit, no number; the forecaster's own chance of this, stated with the estimate: 60%; at least 1.1-fold (0.07 log units) between middle value and limit.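

In this assay compound 4 gives a limit and not a number, so the steps to it from compound 3 and from compound 1 cannot be read, because this value marks only the end of the tested range: the limit of > 47300 nM in this assay, at which 1 of the 4 values shown sits.

Among these compounds, the one readable new step is an at least 1.9-fold higher number from compound 2 to compound 4 (0.28 log units; that floor lies within the scatter), and it adds no measured size beyond the earlier floors at this position. What is new is the kind of group: 2-fluorophenyl, a six-membered aromatic ring of carbon only, now joins pyrimidin-4-yl and furan-2-yl in returning a limit on a saturated chain carbon bound to an amide-type nitrogen, while compound 2 is the one exception that gives an actual number, and its printed floors do not separate it from the others beyond the scatter.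

From the compounds shown here alone, the order among compound 1, compound 3 and compound 4 stays open, since none of them has an actual number in this assay. Also open, going by these compounds, is how a carboxylic acid, an amine or a longer chain at this same place would read in this assay.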